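Working notes: nitro in place of methoxy on compound 2

This account rests on a few compounds, and the source may have more. Where it says the series, first, only, none or still open, it means among the compounds named here.

Compound 1 `O=C(/C=C/c1ccc(NC(=O)Nc2ccc([N+](=O)[O-])cc2)cc1)NO` gives > 50000 nM as a limit
Compound 2 `COc1ccc(NC(=O)Nc2ccc(CCC(=O)NO)cc2)cc1` gives > 50000 nM as a limit

In a functional assay on MCF7 cells (Homo sapiens) for cytotoxicity, read by MTT assay, with a stated time of 72 h (a lower number here means a stronger inhibitor, a higher number a weaker inhibitor), compound 2 gives > 50000 nM as a limit and not a number. Among the compounds with values here, both measured compounds stand at the same limit (the limit of > 50000 nM in this assay, at which 2 of the 2 values shown sit), and no step between them can be read. Compound 3 `O=C(CCc1ccc(NC(=O)Nc2ccc([N+](=O)[O-])cc2)cc1)NO` is still to be measured. Compared with compound 2, it has nitro in place of methoxy on an aromatic carbon, para to a large group (nitro in place of methoxy on an aromatic carbon). Compound 1 also carries nitro and gives > 50000 nM as a limit in this assay as well. No step beyond the scatter is expected in this assay in either direction, and a limit is the likeliest report. The estimated step is a number no higher from compound 2 to compound 3 (the limit leaves the size open) on this expectation. For compound 3 the estimated value is 50000 nM with an expected range (25000 nM to 100000 nM).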

Compound 3, half-maximal inhibitory concentration: > 50000 nM
Compound 3 gave a limit, no number; the forecaster's own chance of this, stated with the estimate: 80%; the middle value lies on the limit itself.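

Compound 1, compound 2 and compound 3 all sit at a limit, not a number, in this assay, so no step to compound 3 can be read: the limit of > 50000 nM in this assay, at which 3 of the 3 values shown sit.

The compounds shown leave open whether nitro in place of methoxy, or 2-(hydroxycarbamoyl)ethyl in place of 2-(hydroxycarbamoyl)ethenyl, changes the read-out in this assay at all.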